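The source may hold more compounds than are shown below. What is called first, only, known or untested is meant among the compounds shown, and "the series" means these compounds.

Measured so far:
- compound 1, `ClCc1ccccc1Cn1cnc2c(Cl)nc(Cl)nc21`, 190 nM
- compound 2, `Nc1nc(Cl)c2ncn(Cc3ccc(CCl)cc3)c2n1`, 2750 nM
- compound 3, `ClCc1cccc(Cn2cnc3nc(Cl)nc(Cl)c32)c1`, 750 nM

The three compounds share a core and carry a chloromethyl group on a benzyl substituent. In a functional assay on HCT-116 cells (Homo sapiens) for cytotoxicity, read by sulforhodamine B assay, with a stated time of 48 h (a higher number here means a weaker inhibitor of growth, a lower number a stronger inhibitor of growth), compound 1 gives the lowest of the three numbers. Compound 3, the nearest to it, gives 750 nM, a gap beyond the scatter; compound 2, the furthest, gives 2750 nM, also beyond the scatter. Compound 2 differs from both compound 1 and compound 3 in more than one place, so no single change can be read from its value.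

Compound 4, `Nc1nc(Cl)c2ncn(Cc3ccccc3CCl)c2n1`, has not yet been tested in this assay. It differs from compound 1 in one place: amino in place of chloro on an aromatic carbon. Among the compounds with values here, no measured pair shows this change on its own. Compound 2, which carries the same amino group, gives the highest number of the three, but its benzyl substituent also differs from that of compound 1. On that basis compound 4 is expected to give a higher number than compound 1, with a step of a 3.2-fold higher number from compound 1 to compound 4 (0.50 log units; beyond the scatter) expected. The estimate for compound 4 is 600 nM, in a range from 200 nM to 2000 nM.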

Compound 4, concentration for 50% growth inhibition: 3980 nM
Beside the measured number, compound 4's estimate is 6.6-fold (0.82 log units) below it; the measured number lies above the stated range.
By their numbers in this assay, from the lowest: compound 1; then compound 3; then compounds 2 and 4 (each within the scatter of the next).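

In this assay, within the data shown here, the change of chloro to amino on the aromatic carbon between two ring nitrogen atoms can now be read on its own, with the benzyl substituent of compound 1 kept in place, and it gives a 21-fold higher number from compound 1 to compound 4 (1.32 log units; beyond the scatter), a large loss of growth inhibition that the earlier compounds could not separate from other differences. Among the compounds shown, both of those carrying the amino group sit at the high end, as compound 2 gives 2750 nM and compound 4 gives 3980 nM, two values within the scatter of each other. Nothing available here explains why this single change has so large an effect on the number.

The compounds shown leave open whether the loss is specific to the amino group or would also follow from other groups at this position, such as a methylamino group, a methoxy group or a plain hydrogen. They also leave open whether the same step would hold if the chloromethyl group on the benzyl substituent were replaced by a methyl group.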